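Taking the Methyl Off Compound 2

A few compounds are considered here, and "the series" means these few. Any claim that something is new, unique, unknown or untested is made for them only; others in the source may bear on it.

Measured in an ADME assay on HEK-293T cells (Homo sapiens) for cytotoxicity, read by MTT assay, with a stated time of 48 h; on this read-out higher numbers stand for lower toxicity in this test and lower numbers for higher toxicity in this test:
- Compound 1 `COc1cc(CNC(=O)c2ccc([N+](=O)[O-])s2)ccc1OC(=O)c1ccc([N+](=O)[O-])s1`: 61 ug/mL
- Compound 2 `Cc1cc(CNC(=O)c2ccc([N+](=O)[O-])s2)ccc1OC(=O)c1ccc([N+](=O)[O-])s1`: 168 ug/mL

Of these two compounds, compound 2 has the higher number, 168 ug/mL. Compound 3 `O=C(NCc1ccc(OC(=O)c2ccc([N+](=O)[O-])s2)cc1)c1ccc([N+](=O)[O-])s1` differs from it by one change: hydrogen in place of methyl on an aromatic carbon. For the measured compounds named here, only one measured step bears on this, a 2.8-fold higher number from compound 1 to compound 2 (0.44 log units; beyond the scatter), where methyl replaced methoxy. Going by the values given here, that modest step shows that a small group can move the number, but no measured compound shows what removing the group does. The expected change is therefore small and downward, a 1.5-fold lower number from compound 2 to compound 3 (0.18 log units; within the scatter), possibly no more than the scatter. For compound 3 the estimate is 110 ug/mL, with an expected range from 45 ug/mL to 260 ug/mL.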

Compound 3, half-maximal cytotoxic concentration: 251 ug/mL
Compound 3: middle estimate off by 2.3-fold (0.36 log units), on the low side, within the range that was stated.
By their numbers in this assay, from the lowest: compound 1; then compounds 2 and 3 (each within the scatter of the next).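

In this assay, hydrogen in place of methyl on this aromatic carbon brings a 1.5-fold higher number from compound 2 to compound 3 (0.17 log units; within the scatter) and so leaves the number inside the usual scatter. Hydrogen in place of methoxy brings a 4.1-fold higher number from compound 1 to compound 3 (0.61 log units; beyond the scatter) and so, among these three compounds, only the methoxy compound stands apart, with the lowest number and the highest toxicity in this test. Nothing available here gives a reason for this. The compounds shown leave open how a chlorine atom, an amine or a longer chain on this carbon would read in this assay and whether any such group would stand apart as methoxy does.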